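Phenyl in Place of Pyridin-2-yl: An Expected Small Step

The compounds below may be only part of what the source reports. "The series", "measured", "known", "first", "only" and "open" are said of these compounds alone.

Measured compounds:
compound 1, `Nc1ccccc1NC(=O)c1ccc(CSC(=S)N2CCN(Cc3ccccn3)CC2)cc1`: 20.7%
compound 2, `Nc1ccccc1NC(=O)c1ccc(CSC(=S)N2CCN(c3ccccc3F)CC2)cc1`: 18.7%
compound 3, `Nc1ccccc1NC(=O)c1ccc(CSC(=S)N2CCc3ccc([N+](=O)[O-])cc32)cc1`: 22.1%

In a functional assay on A-375 cells (Homo sapiens) for antiproliferative activity, read by CCK-8 assay, with a stated time of 72 h, tested at 2 uM (a lower number here means a weaker effect, a higher number a stronger effect of the compound at the concentration tested), compound 1 gives 20.7%, the middle of the three numbers. Compound 3 gives 22.1% and compound 2 gives 18.7%; both lie within the scatter of compound 1, so the three cannot be told apart. Compound 4, `Nc1ccccc1NC(=O)c1ccc(CSC(=S)N2CCN(Cc3ccccc3)CC2)cc1`, is still unmeasured. It differs from compound 1 in one place: phenyl in place of pyridin-2-yl on a saturated chain carbon bound to an amine nitrogen in a ring. For the measured compounds named here, the only measured step that bears on this exchange is a number 2 percentage points lower from compound 1 to compound 2 (within the scatter), where the same (pyridin-2-yl)methyl was replaced by another group. Since that step stayed within the scatter, no step beyond the scatter is expected here either, a number 0.7 percentage points lower from compound 1 to compound 4 (within the scatter). For compound 4 the estimate is 20%, with a range from 10% to 30%.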

Compound 4, a percentage reported as inhibition, at one concentration (the size of the read-out at that concentration, not a potency): 10.6%
For compound 4 the middle estimate is 9.4 percentage points above the measured one; the range from low to high includes it.
By their numbers in this assay, from the lowest: compounds 4, 2, 1 and 3 (each within the scatter of the next, the first and the last beyond it).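

In this assay the exchange of pyridin-2-yl for phenyl gives a number 10.1 percentage points lower from compound 1 to compound 4 (beyond the scatter) and is the only step shown that lies beyond the scatter, so this position responds to replacing one ring nitrogen with carbon. By contrast, a number 8.1 percentage points lower from compound 2 to compound 4 (within the scatter) leaves benzyl and 2-fluorophenyl indistinguishable. No available evidence accounts for the change. As far as these compounds go, whether pyridin-3-yl or pyridin-4-yl would hold the value of compound 1 remains open. So does whether an amino group on the phenyl ring of compound 4 would restore it.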